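Furan-2-yl for Phenyl on the Hydrazone Carbon

The source may hold more compounds than are shown below. What is called first, only, known or untested is meant among the compounds shown, and "the series" means these compounds.

Compound 1 `C/C(=N\NC(=O)COc1cccc2cccnc12)c1ccccc1` was run in an ADME assay on MCF7 cells (Homo sapiens) for cytotoxicity, read by MTT assay, with a stated time of 48 h (on this read-out higher numbers stand for weaker inhibition and lower numbers for stronger inhibition), and returns only a limit, > 100000 nM. That limit is the limit of > 100000 nM in this assay, at which 1 of the 2 values shown sits. Compound 2 `c1ccc(-c2c[se]nn2)cc1` has no result in this assay; for compound 2 the entry reads "not determined" (no result reported). Going by the values given here, no step between measured compounds exists, so nothing sets a scale for compound 3 `C/C(=N\NC(=O)COc1cccc2cccnc12)c1ccco1`, which carries furan-2-yl in place of phenyl on a carbon with a double bond to nitrogen. Compound 1 sits at the limit > 100000 nM. Given that, the step from compound 1 to compound 3 in this assay is expected to be a number no higher from compound 1 to compound 3 (the limit leaves the size open), nothing beyond the scatter. Compound 3 is estimated at 100000 nM, within 30000 nM to 300000 nM, most likely reported again as a limit.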

Compound 3, half-maximal inhibitory concentration: > 100000 nM
Compound 3 gave a limit, no number (the forecaster's own chance of this, stated with the estimate: 80%); the middle value lies on the limit itself.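

No step can be read from compound 1 to compound 3 in this assay, since each gives only a limit: the limit of > 100000 nM in this assay, at which 2 of the 3 values shown sit. From the compounds shown here alone, whether furan-2-yl in place of phenyl changes the read-out at all stays open.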